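The source may report more compounds than this note shows. Statements on the series, on what has been measured and on what is new or still open speak of the compounds shown alone.

In a functional assay on JAR cells (Homo sapiens) for inhibition, read by MTT assay, with a stated time of 72 h, tested at 10 uM (a higher number here means more inhibition at the concentration tested (going by the name of the read-out), a lower number less inhibition), compound 2 `CCOC(=O)C1=C(Nc2ccccc2)S/C(=C\c2ccc(C(=O)O)cc2)C1=O` gives 16.8%, the lowest of the three numbers at hand. Compound 3 `CCOC(=O)C1=C(Nc2ccc(OC)cc2)S/C(=C\c2ccc[nH]2)C1=O` gives 27.6% in this assay, the nearest number to compound 2 and still beyond the scatter above it, while compound 1 `CCOC(=O)C1=C(Nc2ccccc2)S/C(=C\c2ccc([N+](=O)[O-])c(O)c2)C1=O` gives 51.2% in this assay, the furthest from compound 2 and likewise beyond the scatter. For the measured compounds named here, no step between measured compounds that differ in one place is available. Compound 4 `CCOC(=O)C1=C(Nc2ccccc2)S/C(=C\c2cc3cccnc3[nH]2)C1=O` differs from compound 2 by a group of 9 heavy atoms (7 carbon, 2 nitrogen; one five-membered aromatic ring with 1 hetero atom, one six-membered aromatic ring with 1 hetero atom) in place of a group of 9 heavy atoms (7 carbon, 2 oxygen; one six-membered aromatic ring of carbon only), on a double-bonded chain carbon bound to a double-bonded ring carbon. Since compound 2 with its 4-carboxyphenyl gives 16.8% and both other compounds stand higher, a moderate upward step in this assay is expected. Compound 4 is estimated at 32%, within a range of 14% to 52%. That estimate means an expected step of a number 15.2 percentage points higher from compound 2 to compound 4 (beyond the scatter).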

Compound 4, a percentage reported as inhibition, at one concentration (the size of the read-out at that concentration, not a potency): 54.3%
The estimate for compound 4 lay 22.3 percentage points below the measured number; measured number outside the range, above it.
By their numbers in this assay, from the lowest: compound 2; then compound 3; then compounds 1 and 4 (each within the scatter of the next).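

For the compounds shown here, this is the first single-place step at this position: in this assay, the group with one five-membered and one six-membered aromatic ring, each with one hetero atom, in place of 4-carboxyphenyl gives a number 37.5 percentage points higher from compound 2 to compound 4 (beyond the scatter). The position therefore responds strongly to this change, although heavy-atom, hydrogen-bond donor and hydrogen-bond acceptor counts match on both sides and neither group carries a net charge. No supporting evidence accounts for the step. The compounds shown leave open how much of it comes from losing the 4-carboxyphenyl and how much from the entering rings. An unsubstituted phenyl at this place would separate the two.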